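Swapping One Halogenated Benzyl Group for Another

The source may report more compounds than this note shows. Statements on the series, on what has been measured and on what is new or still open speak of the compounds shown alone.

Of the compounds shown here, three built on a shared core have been tested in an ADME assay on cells (Mus musculus, strain BALB/c) for cytotoxicity, read by MTT assay, with a stated time of 24 h; on this read-out lower numbers stand for higher toxicity in this test and higher numbers for lower toxicity in this test. Compound 1 `COc1cc(-c2nnc(SCc3ccc([N+](=O)[O-])cc3)o2)ccc1O` gives 688000 nM. Compound 2 `COc1cc(-c2nnc(SCc3cccc(Br)c3)o2)ccc1O` gives 382000 nM, and compound 3 `COc1cc(-c2nnc(SCc3cccc([N+](=O)[O-])c3)o2)ccc1O` gives 392000 nM. Within the data shown here, compound 2 has the lowest of the three numbers, but every gap is within the scatter: the step of a 1.0-fold higher number from compound 2 to compound 3 (0.01 log units; within the scatter) is essentially flat, and the gap between compound 2 and compound 1 is also within the scatter, so no compound can be called more or less toxic than another here.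

Compound 4 `COc1cc(-c2nnc(SCc3ccccc3F)o2)ccc1O` has not yet been measured. It differs from compound 2 in one place: 2-fluorophenyl in place of 3-bromophenyl on a saturated chain carbon bound to a sulfur. Among the measured compounds shown here, the only measured step, a 1.0-fold higher number from compound 2 to compound 3 (0.01 log units; within the scatter), alters the group on the same ring that is exchanged here and produces no movement beyond the scatter. For the measured compounds named here, no measured step puts a 2-fluorophenyl in place of a 3-bromophenyl, so nothing in these data points to a shift in either direction. The step from compound 2 to compound 4 is therefore expected to be a 1.0-fold higher number from compound 2 to compound 4 (0.02 log units; within the scatter), nothing beyond the scatter. For compound 4 in this assay the estimated value is 400000 nM, with a range from 200000 nM to 800000 nM.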

Compound 4, half-maximal cytotoxic concentration: 474000 nM
For compound 4 the middle estimate is 1.2-fold (0.07 log units) below the measured one; the range from low to high includes it.
By their numbers in this assay, from the lowest: compounds 2, 3, 4 and 1 (each within the scatter of the next).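

In this assay, replacing the 3-bromophenyl with a 2-fluorophenyl on a saturated chain carbon bound to a sulfur gives a 1.2-fold higher number from compound 2 to compound 4 (0.09 log units; within the scatter), so compounds 2 and 4 cannot be told apart in this test. The earlier step kept the ring substituent at the same place and exchanged only the bromo for a nitro, whereas this one alters both the halogen and its place on the ring, as the names of the two groups show, and the number still stays within the scatter; the two groups match in their counts of heavy atoms, hydrogen-bond donors and acceptors, and neither carries a net charge. No supporting measurement is available to explain this result. The compounds shown leave open whether an amine or a carboxylic acid on this ring, or a longer chain in place of the single saturated carbon bound to the sulfur, would move the number beyond the scatter. Also open, as far as these compounds go, is how a plain phenyl with no halogen would compare with the 3-bromophenyl of compound 2.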